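This account rests on a few compounds, and the source may have more. Where it says the series, first, only, none or still open, it means among the compounds named here.

Compound 2 `O=C(CCc1ccc(C(F)(F)F)cc1)Nc1ccc2nc(N3CCC4(CCNC4)C3)ccc2c1` holds the lowest of the two numbers recorded so far: in an assay on isolated protein for displacement of a labelled ligand from melanin-concentrating hormone receptor 1 (Homo sapiens) (on this read-out higher numbers stand for weaker inhibition and lower numbers for stronger inhibition), compound 2 gives 0.5 nM. Within the data shown here, the only comparison is compound 1 `CC1CCCN1c1ccc2cc(NC(=O)CCc3ccc(C(F)(F)F)cc3)ccc2n1`, which in this assay gives 5 nM; the step of a 10-fold lower number from compound 1 to compound 2 (1.00 log units; beyond the scatter) came from replacing a single five-membered ring bearing a nitrogen with a pair of such rings on an aromatic carbon. Compound 3 `CCN(CC)c1ccc2cc(NC(=O)CCc3ccc(C(F)(F)F)cc3)ccc2n1` moves in the opposite direction from compound 2: a group of 5 heavy atoms (4 carbon, 1 nitrogen; no ring) in place of a group of 9 heavy atoms (7 carbon, 2 nitrogen; 2 five-membered non-aromatic rings with 1 hetero atom each), on an aromatic carbon, so a diethylamino group with no ring now stands where the two rings stood. Among the measured compounds shown here, only the step from compound 1 to compound 2 bears on this, and it was modest; removing both rings goes further than compound 1 did, so the number is expected to climb at least back toward that of compound 1 and possibly beyond. The expected step is a 30-fold higher number from compound 2 to compound 3 (1.48 log units; beyond the scatter). Compound 3 is therefore estimated at 15 nM. Its expected range runs from 3 nM to 80 nM.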

Compound 3, half-maximal inhibitory concentration: 88 nM
Compound 3: the middle estimate sits 5.9-fold (0.77 log units) below what was measured; measured number above the stated range.
By their numbers in this assay, from the lowest: compound 2; then compound 1; then compound 3.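

In this assay, among these compounds, putting diethylamino, which has no ring, next to the ring nitrogen gives a 180-fold higher number from compound 2 to compound 3 (2.25 log units; beyond the scatter) and also an 18-fold higher number from compound 1 to compound 3 (1.25 log units; beyond the scatter) so the group at this position matters even when the comparison partner carries only one ring. Among the compounds shown here, the earlier pair showed only that the group with two rings gave a lower number than 2-methylpyrrolidin-1-yl, whereas all three compounds now rank with the ring-free group highest and the two-ring group lowest. Nothing measured here explains why these changes shift the number.

Diethylamino and 2-methylpyrrolidin-1-yl differ in more than the ring alone, so the contribution of ring closure stays unresolved. Pyrrolidin-1-yl, piperidin-1-yl or dimethylamino at this position would help separate the ring from the carbon count, and morpholin-4-yl would show how a ring oxygen fares there.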